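This account rests on a few compounds, and the source may have more. Where it says the series, first, only, none or still open, it means among the compounds named here.

Working notes on the series. The shared core is that of compound 1 `Cc1cc(NC(=O)Nc2ccc(C(C)(C)C)cc2)c2ccccc2n1`. In an ADME assay on BJ cells (Homo sapiens) for cytotoxicity, with a stated time of 72 h (on this read-out higher numbers stand for an effect only at larger amounts of compound and lower numbers for an effect already at smaller amounts), compound 1 gives 20000 nM. Compound 3 `COc1ccc(NC(=O)Nc2cc(C)nc3ccccc23)cc1Cl` gives in this assay 23000 nM, and the two numbers lie within the usual scatter of each other, so nothing separates compound 1 from compound 3 on this read-out. Compound 2 `Cc1cc(NC(=O)Nc2ccc3[nH]cnc3c2)c2ccccc2n1` is reported in this assay not as a number but as a limit, > 25000 nM; this is the limit of > 25000 nM in this assay, at which 1 of the 3 values shown sits. Within the data shown here, compound 1 thus stands with compound 3 at the lower end of what has been measured, with only two real numbers and one limit to go on. Among the measured compounds shown here, no two measured compounds differ in a single place, so no measured step is available to lean on.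

Compound 4 `Cc1cc(NC(=O)Nc2ccc(C(=O)O)cc2)c2ccccc2n1` is the next entry. Relative to compound 1 the change is carboxy in place of tert-butyl on an aromatic carbon. Given how close together the numbers of compound 1 and compound 3 sit, and that compound 2 reaches only a limit, no step beyond the scatter is expected in this assay in either direction, with a slight lean toward a higher number. The step expected from compound 1 to compound 4 is a 1.3-fold higher number from compound 1 to compound 4 (0.11 log units; within the scatter). The value expected for compound 4 is 26000 nM, within a range from 14000 nM to 50000 nM.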

Compound 4, half-maximal effective concentration: > 25000 nM
Compound 4 gave a limit, no number; the forecaster's own chance of this, stated with the estimate: 50%; the middle value does not contradict the limit.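

Among these compounds, the step from tert-butyl to carboxy on an aromatic carbon, para to a large group, is the only single-place comparison so far, and in this assay it reads an at least 1.2-fold higher number from compound 1 to compound 4 (0.09 log units; that floor lies within the scatter). The value of compound 4 of > 25000 nM is a limit of the assay and not a number, so the step has a floor but no upper end, and that floor alone shows no change at this position. Carboxy, with its hydrogen-bond donor and acceptor, in place of tert-butyl, with neither, does not bring a lower number here, and the limit now holds for more of the compounds shown: the limit of > 25000 nM in this assay, at which 2 of the 4 values shown sit.

On these data alone, whether the true number for compound 4 lies near the floor or far past it remains open, and with it whether this step leaves the scatter at all. Also open, as far as these compounds go, is how an amine or a longer chain on this aromatic carbon would read, and whether the same change elsewhere on the shared core would behave alike.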